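A fluoro for chloro swap at a limit

The source may report more compounds than this note shows. Statements on the series, on what has been measured and on what is new or still open speak of the compounds shown alone.

Compound 1 `C[C@H]1CCCC[C@H]1NC(=O)c1cc2c(Cl)cc(Cl)cc2[nH]1`: < 4000 nM, a limit
Compound 2 `CC1CCC(NC(=O)c2cc3c(Cl)cc(Cl)cc3[nH]2)CC1`: < 4000 nM, a limit

Both compounds were read in a physicochemical assay for solubility, measured as thermodynamic solubility, with a stated time of 24 h, at pH 6.8 (on this read-out lower numbers stand for lower solubility and higher numbers for higher solubility), and neither gave a number. Compound 2 stands only at its limit of < 4000 nM. The same holds for the pair as a whole: the limit of < 4000 nM in this assay, at which 2 of the 2 values shown sit. Among the compounds with values here, the one measured step is a step that the two limits leave unreadable from compound 1 to compound 2, and it offers no size to carry forward. It also concerns another part of the molecule. Compound 3 `CC1CCC(NC(=O)c2cc3c(Cl)cc(F)cc3[nH]2)CC1` differs from compound 2 by fluoro in place of chloro on an aromatic carbon. With no readable step to draw on, no change beyond the scatter is expected in this assay. For compound 3 the expected step is a step that the limit leaves unreadable from compound 2 to compound 3. Compound 3 is estimated at 3000 nM, with an expected range from 1000 nM to 8000 nM.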

Compound 3, solubility: < 4000 nM
Compound 3: a limit, no number; the forecaster's own chance of this, stated with the estimate: 65%; the middle value lies beyond the limit too.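

Compound 2 and compound 3 both give only a limit in this assay, and no step can be read for fluoro in place of chloro on an aromatic carbon. On these data alone, what stays open is where the actual solubility of each compound lies, and whether this swap changes it at all.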